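Aryl for alkyl on the chain carbon of compound 2

The compounds below may be only part of what the source reports. "The series", "measured", "known", "first", "only" and "open" are said of these compounds alone.

Measured in an assay on membranes from Chem-1 cells for displacement of a labelled ligand from prostaglandin E2 receptor EP3 subtype (Homo sapiens), read by scintillation counting, with a stated time of 2 h; a higher number here means a weaker inhibitor, a lower number a stronger inhibitor:
compound 1 `CCC(/C=C1\OC(=O)NC1=O)(CC)c1ccc(-c2ccc3cc(F)cc(F)c3c2)[nH]c1=O` gives 28 nM
compound 2 `CCC(CC)C(/C=C1\OC(=O)NC1=O)c1ccc(-c2ccc3cccc(F)c3c2)[nH]c1=O` gives 13 nM
compound 3 `CC(C)[C@@H](c1ccc(-c2ccc3cccc(F)c3c2)[nH]c1=O)[C@H]1OC(=O)NC1=O` gives 27 nM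

Compound 2 holds the lowest number of the three in this assay; compound 3 and compound 1 both sit beyond the scatter above it, so the branched group on that chain carbon has moved the number only modestly across the set. Compound 4 `O=C1NC(=O)/C(=C/C(c2ccccc2)c2ccc(-c3ccc4cccc(F)c4c3)[nH]c2=O)O1` is not yet measured. Its change from compound 2: phenyl in place of pentan-3-yl on a saturated chain carbon bound to an aromatic carbon and a double-bonded chain carbon. Nothing measured covers an aromatic group at that place, so the direction rests on the narrow spread seen so far. For compound 4 a small weakening step is expected, a 2.2-fold higher number from compound 2 to compound 4 (0.33 log units; beyond the scatter), beyond the scatter but not large. Compound 4 is estimated at 28 nM, with a range of 9 nM to 90 nM.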

Compound 4, inhibition constant in the prostaglandin E2 receptor EP3 subtype assay: 23 nM
The estimate for compound 4 lay 1.2-fold (0.09 log units) above the measured number; the measured number falls inside the stated range.
By their numbers in the prostaglandin E2 receptor EP3 subtype assay, from the lowest: compounds 2, 4, 3 and 1 (each within the scatter of the next, the first and the last beyond it).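

For the compounds shown here, in the prostaglandin E2 receptor EP3 subtype assay phenyl in place of pentan-3-yl on this saturated chain carbon gives a 1.8-fold higher number from compound 2 to compound 4 (0.25 log units; within the scatter) and so shows that an aromatic ring is tolerated at a place where the earlier compounds carried only alkyl groups. In a physicochemical assay for solubility, in phosphate buffer, measured as kinetic solubility (on this read-out lower numbers stand for lower solubility and higher numbers for higher solubility), compound 2 gives 33700 nM and compound 4 gives 32800 nM and these two values lie within the scatter of each other. No measurement at hand offers a reason for either reading.

As far as these compounds go, whether a fluorine, an amine or a carboxylic acid on the phenyl ring would keep these readings unchanged remains open. A pyridine ring or a cyclohexyl group at this place also remains untested in the compounds shown.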